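Chain shortening on a bis-benzimidazole topoisomerase series

The compounds below may be only part of what the source reports. "The series", "measured", "known", "first", "only" and "open" are said of these compounds alone.

Measured so far:
Compound 1 `C#CCOCCCCCCCCOc1ccc(-c2nc3ccc(-c4nc5ccc(N6CCN(C)CC6)cc5[nH]4)cc3[nH]2)cc1`: in an assay on isolated protein for inhibition of DNA topoisomerase 1 (Homo sapiens), with a stated time of 30 min (a lower number here means a stronger inhibitor, a higher number a weaker inhibitor), compound 1 gives > 50000 nM, which is a limit of the assay.
Compound 2 `CN1CCN(c2ccc3nc(-c4ccc(OCc5cn(CCCCN=[N+]=[N-])nn5)cc4)[nH]c3c2)CC1`: in this assay compound 2 gives > 50000 nM, also a limit of the assay.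

Compound 1 thus stands at the limit, as does compound 2; both values sit at the limit of > 50000 nM in this assay, at which 2 of the 2 values shown sit. Compound 3 `C#CCOCCCCCCOc1ccc(-c2nc3ccc(-c4nc5ccc(N6CCN(C)CC6)cc5[nH]4)cc3[nH]2)cc1` differs from compound 1 by propargyloxy in place of 2-(propargyloxy)ethyl on a saturated chain carbon, six bonds along the chain from an oxygen on an aromatic ring. Among the compounds with values here, no measured step bears on this change. The expectation is no movement beyond the scatter, so the step that the limit leaves unreadable from compound 1 to compound 3 is estimated as essentially flat. Compound 3 is expected to sit around 80000 nM, within 30000 nM to 300000 nM, most likely reported again as a limit.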

Compound 3, half-maximal inhibitory concentration: > 50000 nM
Compound 3: no number, only a limit; the forecaster's own chance of this, stated with the estimate: 85%; the middle value does not contradict the limit.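

In this assay, compound 1 and compound 3 both stand at a limit of the assay, so no step between them can be read: the limit of > 50000 nM in this assay, at which 3 of the 3 values shown sit.

The compounds shown leave open whether any chain length on the shared core gives a readable value in this assay.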